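The source may hold more compounds than are shown below. What is called first, only, known or untested is meant among the compounds shown, and "the series" means these compounds.

Measured compounds in a functional assay on cells for antagonist activity at Free fatty acid receptor 1 (Homo sapiens), read by TR-FRET and inositol phosphate accumulation, with a stated time of 2 h; on this read-out higher numbers stand for weaker inhibition and lower numbers for stronger inhibition:
compound 1 `COc1cccc(OCc2cc(C)nc(-c3ccccn3)n2)c1` gives 2000 nM;
compound 2 `Cc1cc(COc2cccc(C#N)c2)nc(-c2ccccn2)n1` gives 2510 nM;
compound 3 `Cc1cc(COc2ccc(C#N)cc2)nc(-c2ccccn2)n1` gives 31600 nM.

Compound 2 holds the second highest of the three numbers. Its nearest neighbour is compound 1, whose number lies within the scatter of compound 2; the step of a 1.3-fold higher number from compound 1 to compound 2 (0.10 log units; within the scatter) therefore shows no change to speak of. Compound 3, in which the cyano sits elsewhere on the same ring, gives a number well beyond the scatter of compound 2.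

Compound 4 `Cc1cc(COc2cccc(S(C)(=O)=O)c2)nc(-c2ccccn2)n1` has not been measured. It differs from compound 2 in one place: methylsulfonyl in place of cyano on an aromatic carbon. Going by the values given here, the only measured step that bears on it is the swap at this same position from compound 1 to compound 2, which stayed within the scatter. Among the compounds with values here, no measured pair shows a methylsulfonyl anywhere, so the expected size of the step in this assay rests on that one precedent alone. A step of modest size, if any, is expected, with the direction uncertain; the estimate for compound 4 is 4000 nM, between 1500 nM and 12000 nM, which corresponds to an expected step of a 1.6-fold higher number from compound 2 to compound 4 (0.20 log units; within the scatter).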

Compound 4, half-maximal inhibitory concentration: > 39800 nM
Compound 4 ended at the assay's limit (the forecaster's own chance of this, stated with the estimate: 10%); middle value at least 9.9-fold (0.99 log units) away from the limit.
By their numbers in this assay, from the lowest: compounds 1 and 2 (each within the scatter of the next); then compound 3. At a limit, above all of these: compound 4.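

In this assay this position, on an aromatic carbon meta to a large group, does not treat every swap alike: the earlier exchange of methoxy for cyano stayed within the scatter, whereas methylsulfonyl gives an at least 15-fold higher number from compound 2 to compound 4 (1.20 log units; beyond the scatter) and an at least 19-fold higher number from compound 1 to compound 4 (1.29 log units; beyond the scatter). Compound 4 gives > 39800 nM, which is a limit of the assay and not a number: the limit of > 39800 nM in this assay, at which 1 of the 4 values shown sits. Methylsulfonyl differs from cyano in heavy atoms, double bonds and hydrogen-bond acceptors all at once, so this single step does not show which of these differences counts.

From the compounds shown here alone, whether an amine, a carboxylic acid or a longer chain at this position would fall with methoxy and cyano or with methylsulfonyl stays open. Going by these compounds, how far the true value of compound 4 lies past the limit also stays open.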